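This account rests on a few compounds, and the source may have more. Where it says the series, first, only, none or still open, it means among the compounds named here.

Three compounds have been examined in a functional assay on HCT-116 cells (Homo sapiens) for cytotoxicity, read by MTT assay, with a stated time of 48 h, in the presence of a further agent that is not named here; on this read-out lower numbers stand for an effect already at smaller amounts and higher numbers for an effect only at larger amounts of compound. Compound 1 `Cn1nc(C(F)(F)F)c2c(-c3ccccc3)cc(NNC(=O)Nc3cc(Cl)nc(Cl)c3)nc21` gives 18100 nM, compound 3 `COc1cc(NC(=O)NNc2cc(-c3ccc(F)cc3)c3cnn(C)c3n2)cc(Cl)n1` gives 75300 nM, and compound 2 `CCCc1cc(NNC(=O)Nc2cc(Cl)nc(Cl)c2)nc2c1cnn2C` gives 76200 nM. Compound 2 holds the highest of these three numbers; its value and that of compound 3 lie within the scatter of each other, whereas compound 1 lies beyond the scatter, with a lower number than compound 2. Compound 4 `CC(C)c1cc(NNC(=O)Nc2cc(Cl)nc(Cl)c2)nc2c1cnn2C` has not been measured in this assay. It differs from compound 2 by isopropyl in place of propyl on an aromatic carbon. Among the compounds with values here, with no measured step of this kind among the three compounds, the step from compound 2 to compound 4 is expected to be small, with no direction beyond the scatter, a 1.1-fold lower number from compound 2 to compound 4 (0.04 log units; within the scatter). Compound 4 is therefore estimated at 70000 nM, in a range from 30000 nM to 170000 nM.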

Compound 4, half-maximal effective concentration: 17200 nM
Estimate against measurement, compound 4: 4.1-fold (0.61 log units) above, and the stated range ends above it.
By their numbers in this assay, from the lowest: compounds 4 and 1 (each within the scatter of the next); then compounds 3 and 2 (each within the scatter of the next).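

In this assay, the place opposite the ring nitrogen responds to the shape of the chain alone: with the same atoms joined differently, isopropyl in place of propyl gives a 4.4-fold lower number from compound 2 to compound 4 (0.65 log units; beyond the scatter). Within the data shown here, the earlier compounds held no step at this place, so this pair is the first to show that branching there can matter. Nothing at hand accounts for the step. The compounds shown leave open whether a tert-butyl group, a cyclopropyl ring or an amine at this place would read like isopropyl or like propyl.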